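From bromo to cyano on the benzamide ring

The compounds below may be only part of what the source reports. "The series", "measured", "known", "first", "only" and "open" are said of these compounds alone.

Compound 1 `CCCC(=O)Nc1cccc(NC(=O)COc2ccc3c(=O)ccoc3c2)c1` gives 1430 nM in an assay on isolated protein for inhibition of Rho-associated protein kinase 1 (Homo sapiens), read by scintillation counting, radiometric assay and 33P incorporation, with a stated time of 40 min, in the presence of a further agent that is not named here; on this read-out lower numbers stand for stronger inhibition and higher numbers for weaker inhibition. Within the data shown here, compound 2 `O=C(COc1ccc2c(=O)ccoc2c1)Nc1cccc(NC(=O)c2ccc(Br)cc2)c1` gives 303 nM in this assay, the lowest of the two numbers measured so far; the step of a 4.7-fold lower number from compound 1 to compound 2 (0.67 log units; beyond the scatter) put 4-bromophenyl in place of propyl on a carbonyl carbon. Compound 3 `N#Cc1ccc(C(=O)Nc2cccc(NC(=O)COc3ccc4c(=O)ccoc4c3)c2)cc1` differs from compound 2 by cyano in place of bromo on an aromatic carbon. Among the measured compounds shown here, the one measured step exchanged a whole side group, so it bears only loosely on this smaller exchange on the ring. The expected step is therefore a 1.3-fold higher number from compound 2 to compound 3 (0.12 log units; within the scatter), no larger than modest. Compound 3 is estimated at 400 nM in this assay, within a range from 150 nM to 1200 nM.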

Compound 3, half-maximal inhibitory concentration: 123 nM
Beside the measured number, compound 3's estimate is 3.3-fold (0.51 log units) above it; measured number below the stated range.
By their numbers in this assay, from the lowest: compound 3; then compound 2; then compound 1.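

Exchanging a single small group on the ring is enough to move the number in this assay: cyano in place of bromo gives a 2.5-fold lower number from compound 2 to compound 3 (0.39 log units; beyond the scatter). With 4-cyanophenyl in place of propyl the full exchange reaches a 12-fold lower number from compound 1 to compound 3 (1.07 log units; beyond the scatter), so the group on the ring, not the ring alone, helps set the number. Nothing shown here explains why cyano gives the lower number. From the compounds shown here alone, whether an amine, a carboxylic acid or a methoxy group on this same ring carbon would go lower still remains open.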